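Halogen exchange on the aromatic ring: a series at its limit

The source may hold more compounds than are shown below. What is called first, only, known or untested is meant among the compounds shown, and "the series" means these compounds.

Measured in a functional assay on the whole organism for positive allosteric modulation, with Mus musculus as the target; a higher number here means that more compound is needed for the effect, a lower number that less compound is needed:
compound 1 `CCC(=O)N(c1ccc(Cl)cc1)C1CCCC1N(C)C`: > 50 mg/kg
compound 2 `CCC(=O)N(c1ccc(F)cc1)C1CCCC1N(C)C`: > 50 mg/kg

Both entries are limits of the assay and not numbers.

Compound 2 stands at > 50 mg/kg in this assay, which is a limit. The evidence so far is the limit of > 50 mg/kg in this assay, at which 2 of the 2 values shown sit. The next compound is compound 3 `CCC(=O)N(c1ccc(Br)cc1)C1CCCC1N(C)C`, with bromo in place of fluoro on an aromatic carbon.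

For the measured compounds named here, one measured step bears on this change, also an exchange of halogens on an aromatic carbon: a step that the two limits leave unreadable from compound 1 to compound 2. It gives neither a size nor a direction, so no step beyond the scatter is expected in this assay. The estimated step is a step that the limit leaves unreadable from compound 2 to compound 3. For compound 3 the expected value is 60 mg/kg, with an estimated range from 25 mg/kg to 150 mg/kg. A report as a limit is the likeliest outcome.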

Compound 3, dose for half-maximal effect: > 50 mg/kg
Compound 3 ended at the assay's limit; the forecaster's own chance of this, stated with the estimate: 80%; the middle value is on the limit's open side.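

No step can be read among compound 1, compound 2 and compound 3 in this assay: all three entries are limits of the assay, not numbers. The compounds shown leave open how chloro, fluoro and bromo compare, and whether the shared core can give a measurable dose for half-maximal effect at all.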